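The compounds below may be only part of what the source reports. "The series", "measured", "known", "first", "only" and "open" are said of these compounds alone.

Compound 1 `O=C(c1ccc(NCc2cncn2Cc2ccc(-c3ccccc3)cc2)cc1-c1ccccc1)N1CCCCC1` — in a toxicity assay on NIH3T3 cells (Mus musculus) for cytotoxicity, read by resazurin assay (on this read-out higher numbers stand for an effect only at larger amounts of compound and lower numbers for an effect already at smaller amounts), compound 1 gives > 1000 nM, which is a limit of the assay and not a number.
Compound 2 `COC(=O)c1ccc(NCc2cncn2Cc2ccc(Cl)cc2)cc1-c1ccccc1` — compound 2 gives 25000 nM.
Compound 3 `COC(=O)c1ccc(NCc2cncn2Cc2ccc(F)cc2F)cc1-c1ccccc1` — compound 3 gives > 1000 nM, again a limit of the assay.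

Compound 1 thus stands only at a limit; the picture across the series is the limit of > 1000 nM in this assay, at which 2 of the 3 values shown sit. Among the compounds with values here, the one step between measured neighbours, a step that the limit leaves unreadable from compound 2 to compound 3, concerns a different change and its size cannot be read. Compound 4 `c1ccc(-c2ccc(Cn3cncc3CNc3ccc(-c4nc5ccccc5o4)c(-c4ccccc4)c3)cc2)cc1` differs from compound 1 by 1,3-benzoxazol-2-yl in place of (piperidin-1-yl)carbonyl on an aromatic carbon. Within the data shown here, no measured step bears on this change, so no direction is expected beyond the scatter, and compound 4 is estimated to sit near the same limit. The estimate for compound 4 is 20000 nM (range 3000 nM to 100000 nM), meaning an expected step that the limit leaves unreadable from compound 1 to compound 4.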

Compound 4, half-maximal effective concentration: > 10000 nM
Compound 4 was reported as a limit; the forecaster's own chance of this, stated with the estimate: 60%; the middle value is on the limit's open side.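

Within the data shown here, compound 1 and compound 4 both stand only at limits of the assay, so no step between them can be read. On these data alone, whether 1,3-benzoxazol-2-yl in place of (piperidin-1-yl)carbonyl shifts the cytotoxicity at all stays open.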